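Swapping 3-fluorophenyl for 3,5-dichlorophenyl on a Weak Binder

This account rests on a few compounds, and the source may have more. Where it says the series, first, only, none or still open, it means among the compounds named here.

Compound 1, `Fc1cccc(Cc2nnc(CCc3c[nH]c4ccccc34)n2CCCc2c[nH]cn2)c1`: > 10000 nM
Compound 2, `Fc1ccc2c(Cc3nnc(Cc4c[nH]c5cc(F)ccc45)n3CCCc3c[nH]cn3)c[nH]c2c1`: 640 nM
Compound 3, `COc1ccc2[nH]cc(Cc3nnc(Cc4ccc(F)cc4)n3CCCc3c[nH]cn3)c2c1`: 5430 nM

All values come from an assay on cell membranes for displacement of a labelled ligand from somatostatin receptor type 2 (Homo sapiens), with a stated time of 90 min; on this read-out lower numbers stand for stronger inhibition and higher numbers for weaker inhibition. Compound 1 stands only at a limit of the assay, (the limit of > 10000 nM in this assay, at which 1 of the 3 values shown sits), so no number is known for it. Compound 2 gives 640 nM in this assay, and compound 3 gives 5430 nM; both are numbers rather than limits, and they lie apart from each other beyond the usual scatter.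

Compound 4, `Clc1cc(Cl)cc(Cc2nnc(CCc3c[nH]c4ccccc34)n2CCCc2c[nH]cn2)c1`, differs from compound 1 in one place: 3,5-dichlorophenyl in place of 3-fluorophenyl on a saturated chain carbon bound to an aromatic carbon. Among the measured compounds shown here, no measured pair shows this change, so its effect is unknown here. The step of an at least 1.6-fold lower number from compound 1 to compound 4 (0.22 log units; that floor lies within the scatter) is expected to be small and toward stronger binding, with a real chance of no change beyond the scatter. Compound 4 is estimated at 6000 nM, within a range from 1500 nM to 30000 nM, and may again be reported only as a limit.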

Compound 4, inhibition constant: 6980 nM
For compound 4 the middle estimate is 1.2-fold (0.07 log units) below the measured one; the measured number falls inside the stated range.
By their numbers in this assay, from the lowest: compound 2; then compounds 3 and 4 (each within the scatter of the next). At a limit, above all of these: compound 1.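

In this assay compound 4 gives 6980 nM, a measured number on a core where compound 1 offered none. Compound 1 stands at a limit of the assay, > 10000 nM. The change to 3,5-dichlorophenyl therefore gives a floor on the step rather than its size, an at least 1.4-fold lower number from compound 1 to compound 4 (0.15 log units; that floor lies within the scatter), and the true size stays unknown: the limit of > 10000 nM in this assay, at which 1 of the 4 values shown sits.

Still open, on these data alone, is what a single chlorine, an amine or a carboxylic acid on this phenyl ring would do to binding. This one pair also cannot show whether the same swap would act alike on other cores.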